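Trading the Chain Amine for Bromine on the Shared Core

The compounds below may be only part of what the source reports. "The series", "measured", "known", "first", "only" and "open" are said of these compounds alone.

Within the data shown here, compound 1 `NCCCc1ccc(-c2ccc(-c3cccs3)s2)s1` is the one member of this set with a single number in an ADME assay on MDCK cells (Canis lupus familiaris) for cytotoxicity, read by MTT assay, with a stated time of 2 days (on this read-out lower numbers stand for higher toxicity in this test and higher numbers for lower toxicity in this test), where compound 1 gives 18900 nM. Compound 3 `NCCCc1ccc(-c2ccc(-c3ccc(-c4cccs4)s3)s2)s1` is reported only as a limit of the assay, > 200000 nM. For compound 2 `O=C(NCCCCc1ccc(-c2ccc(-c3ccc(CCCCNC(=O)c4cc(F)cc(C(F)(F)F)c4)s3)s2)s1)c1cc(F)cc(C(F)(F)F)c1` the result is "not determined" (no result reported). Among the measured compounds shown here, the one measured step, an at least 10-fold higher number from compound 1 to compound 3 (1.02 log units; beyond the scatter), concerns thiophen-2-yl in place of hydrogen on an aromatic carbon. Compound 4 `BrCCCc1ccc(-c2ccc(-c3cccs3)s2)s1` differs from compound 1 elsewhere: bromo in place of amino on a saturated chain carbon, three bonds along the chain from an aromatic carbon. For the measured compounds named here, no measured step touches a change of this kind, so nothing in the data points to a shift beyond the scatter in either direction. Because compound 1 gives 18900 nM, compound 4 is estimated at 19000 nM, with a range from 6000 nM to 60000 nM. The step of a 1.0-fold higher number from compound 1 to compound 4 (0.00 log units; within the scatter) is expected to stay within the scatter.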

Compound 4, half-maximal cytotoxic concentration: 35300 nM
For compound 4 the middle estimate is 1.9-fold (0.27 log units) below the measured one; low and high end bracket the measured number.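

Putting bromo in place of amino on a saturated chain carbon, three bonds along the chain from an aromatic carbon, gives a 1.9-fold higher number from compound 1 to compound 4 (0.27 log units; within the scatter). Among these compounds, this is the first reading at the chain end, as the one earlier step concerned an aromatic carbon, and here the amino group is exchanged without a shift beyond the scatter. Nothing at hand bears on why this exchange leaves the two compounds so close. As far as these compounds go, it remains open how a carboxylic acid or a hydroxyl group at this chain end would read, and whether a longer chain would read the same.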